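A Chloro Substituent Added to an Inactive Parent

This account rests on a few compounds, and the source may have more. Where it says the series, first, only, none or still open, it means among the compounds named here.

Compound 1 `O=S(=O)(CC1=NCCS1)C1=NNCC1c1ccccc1` was tested in a functional assay, read by Griess assay, with a stated time of 150 min, tested at 75 ug/mL (a lower number here means a weaker effect, a higher number a stronger effect of the compound at the concentration tested), and compound 1 came out as "not active" (no number reported) there, so no single number marks where it stands. Going by the values given here, a differently built relative, compound 2 `O=S(=O)(CC1=NCCO1)c1c(-c2ccccc2)nn(-c2ccccc2)c1-c1ccccc1`, gives 59% in this assay, but no step links it to compound 1. Compound 3 `O=S(=O)(CC1=NCCS1)C1=NNCC1c1ccc(Cl)cc1` is yet to be tested. It differs from compound 1 by chloro in place of hydrogen on an aromatic carbon. With compound 1 already inactive, the step in this assay is expected to be small, upward if anything, and likely within the scatter. Compound 3 is therefore estimated at 15%, between 0% and 40%.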

Compound 3, a percentage reported as activity, at one concentration (the size of the read-out at that concentration, not a potency): "not active" (no number reported)
Compound 3: no number reported; there is nothing to compare the estimate with.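

In this assay compound 1 gives "not active" (no number reported) and compound 3 gives "not active" (no number reported) so no step can be read between them. These compounds leave open whether phenyl to 4-chlorophenyl would change the read-out on a measurably active compound. No measured evidence bears on this result.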